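Closing a fluoroalkyl amide into a ring: expected efficacy

The source may report more compounds than this note shows. Statements on the series, on what has been measured and on what is new or still open speak of the compounds shown alone.

Compound 1, `Cc1nc(S(C)(=O)=O)ccc1Oc1ncnc(OC2CCN(C(=S)OC(C)C)CC2)c1F`: 47%
Compound 2, `Cc1nc(S(C)(=O)=O)ccc1Oc1ncnc(OC2CCN(C(=O)C(C)(C)F)CC2)c1F`: 74%

Both values come from a functional assay on isolated protein for inhibition of Glucose-dependent insulinotropic receptor (Rattus norvegicus), read by HTRF and cAMP accumulation; a higher number here means a larger maximal response, a lower number a smaller maximal response. Among the compounds with values here, of the two numbers measured so far, compound 2 stands highest; the only other compound, compound 1, sits a step lower, and that step, a number 27 percentage points higher from compound 1 to compound 2 (beyond the scatter), is beyond the scatter. Compound 3, `Cc1nc(S(C)(=O)=O)ccc1Oc1ncnc(OC2CCN(C(=O)C3(F)CCC3)CC2)c1F`, has not yet been measured. It differs from compound 2 by a group of 5 heavy atoms (4 carbon, 1 fluorine; one four-membered non-aromatic ring of carbon only) in place of a group of 4 heavy atoms (3 carbon, 1 fluorine; no ring), on a carbonyl carbon. Within the data shown here, the one measured step touches the same end of the molecule, the side group carried by the amine nitrogen in the ring, and shows that changes there can move the maximal response by a modest amount. However, that step swapped a whole side group, whereas the change to compound 3 keeps the amide carbonyl and only joins the carbon bearing the fluorine into a four-membered ring. Among the measured compounds shown here, no measured pair speaks to such a ring closure, so no direction can be read from the data. Compound 3 is therefore expected to stay near compound 2, at an estimated 70%, with a range from 50% to 90%. The expected step is a number 4 percentage points lower from compound 2 to compound 3 (within the scatter), within the scatter.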

Compound 3, largest response reached (reported as efficacy), in percent of the reference or control that the assay uses: 91%
Beside the measured number, compound 3's estimate is 21 percentage points below it, outside the stated range (above it).
By their numbers in this assay, from the lowest: compound 1; then compound 2; then compound 3.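

In this assay, the change gives a number 17 percentage points higher from compound 2 to compound 3 (beyond the scatter), which shows that the maximal response at this position can shift even when the amide carbonyl stays in place and only the group on the carbonyl carbon is altered. The earlier step replaced a whole side group, whereas here the 1-fluoro-1-methylethyl group is joined into a four-membered carbon ring, and the step over the thiocarbamate, a number 44 percentage points higher from compound 1 to compound 3 (beyond the scatter), is large, placing compound 3 highest of the three in this assay. Nothing available explains why the ring raises the response, so the size of the step is all that can be reported.

The three compounds leave open whether the rise comes from the ring itself or simply from the extra carbon, a question that a cyclopropyl or cyclopentyl ring bearing the same fluorine on the carbon attached to the carbonyl could help to answer. They also leave open how much the fluorine matters to this result, which a plain cyclobutyl group or one carrying a hydroxyl in place of the fluorine would test directly.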